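Swapping Isopropyl for Carboxy on Compound 3

The compounds below may be only part of what the source reports. "The series", "measured", "known", "first", "only" and "open" are said of these compounds alone.

Compound 1 `c1ccc(C(CC2CCCCC2)Nc2nc3ccccc3o2)cc1`: 340 nM; 8 nM; 6 nM (3 entries)
Compound 2 `Clc1ccccc1C(CC1CCCCC1)Nc1nc2ccccc2o1`: 80 nM
Compound 3 `CC(C)c1ccc2oc(NC(CC3CCCCC3)c3ccccc3)nc2c1`: 6 nM

In a functional assay for inhibition, with Homo sapiens as the target (on this read-out higher numbers stand for weaker inhibition and lower numbers for stronger inhibition), compound 3 gives 6 nM and compound 2 gives 80 nM, a gap beyond the usual scatter of repeat measurements. Compound 1 has no single number, as shown by the several entries of compound 1 in this assay, 340 nM; 8 nM; 6 nM (3 entries), so readings in this series carry real uncertainty.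

The unmeasured compound 4 `O=C(O)c1ccc2oc(NC(CC3CCCCC3)c3ccccc3)nc2c1` differs from compound 3 in one place: carboxy in place of isopropyl on an aromatic carbon. This puts carboxy in place of isopropyl on an aromatic carbon. Within the data shown here, no measured pair here shows a change in one place, so this swap has no direct precedent. Compound 3 at 6 nM lies at the low end of the numbers seen, which leaves more room for the number to rise than to fall. A step beyond the scatter is therefore expected, toward a higher number and weaker inhibition. The expected change is a step of a 25-fold higher number from compound 3 to compound 4 (1.40 log units; beyond the scatter). Compound 4 is estimated at 150 nM, with an expected range of 15 nM to 1500 nM.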

Compound 4, half-maximal inhibitory concentration: 150 nM
Compound 4: middle estimate and measured number agree at the digits printed; measured number inside the range.
By their numbers in this assay, from the lowest: compound 3; then compounds 2 and 4 (each within the scatter of the next).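

Among these compounds, this is the first single-place step, and it shows that this aromatic carbon is sensitive to what it carries: in this assay, the swap gives a 25-fold higher number from compound 3 to compound 4 (1.40 log units; beyond the scatter). Isopropyl and carboxy each count 3 heavy atoms, so the step comes with no change in that count, while the entering carboxy brings a hydrogen-bond donor, a hydrogen-bond acceptor and a double bond outside the aromatic rings. The exact size of the step is less firm than a single figure suggests, since repeat readings in this series can differ widely: the several entries of compound 1 in this assay, 340 nM; 8 nM; 6 nM (3 entries)

With only one swap at this place, the compounds shown cannot tell which feature of carboxy goes with the weaker inhibition. A methyl ester, a primary amide or an amine on the same carbon would help to separate these features.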